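Series notes: the step from compound 3 to compound 4

The source may report more compounds than this note shows. Statements on the series, on what has been measured and on what is new or still open speak of the compounds shown alone.

Within the data shown here, in an ADME assay on L6 cells (Rattus norvegicus) for cytotoxicity, read by resazurin assay, with a stated time of 72 h (on this read-out lower numbers stand for stronger inhibition and higher numbers for weaker inhibition), compound 3 `Cc1ccc(C(O)(c2ccc(Cl)cc2)c2cccnc2)cc1` gives 61000 nM and stands level, within the scatter, with compound 2 `OC(c1ccc(Cl)cc1)(c1cccnc1)c1ccccc1Cl` at 61300 nM on the numbers so far.

Compound 1 `OC(c1ccc(Cl)cc1)(c1cncnc1)c1ccccc1F` reads > 100000 nM as a limit of the assay and not a number.

The next compound to be read is compound 4 `OC(c1ccc(Cl)cc1)(c1cccnc1)c1ccccc1F` which differs from compound 3 by 2-fluorophenyl in place of 4-methylphenyl on a saturated chain carbon bound to two aromatic carbons and an oxygen on a saturated carbon with the rest of the structure unchanged.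

Among the measured compounds shown here, one measured step bears on this change: 4-methylphenyl in place of 2-chlorophenyl on the same carbon, a 1.0-fold lower number from compound 2 to compound 3 (0.00 log units; within the scatter) and so no step beyond the scatter is expected in this assay for this swap.

For the measured compounds named here, compound 1 also carries 2-fluorophenyl, but it differs from compound 4 elsewhere and its reading is a limit, so it sets no size for this step.

The expected change is a 1.1-fold higher number from compound 3 to compound 4 (0.05 log units; within the scatter) and this estimate stays within the scatter.

For compound 4 the estimated value is 68000 nM with an expected range of 38000 nM to 100000 nM and a reading at the limit of the assay remains possible.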

Compound 4, half-maximal inhibitory concentration: > 100000 nM
Compound 4: no number, only a limit; the forecaster's own chance of this, stated with the estimate: 20%; middle value at least 1.4-fold (0.16 log units) from the limit.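

In this assay, the change to 2-fluorophenyl on the saturated chain carbon gives an at least 1.6-fold higher number from compound 3 to compound 4 (0.21 log units; that floor lies within the scatter), and fluoro in place of chloro on an aromatic carbon gives an at least 1.6-fold higher number from compound 2 to compound 4 (0.21 log units; that floor lies within the scatter). Both figures are floors and not measured sizes, so neither change is shown to move the reading beyond the scatter, yet neither step has an upper bound, whereas the step from compound 2 to compound 3 had a readable size and showed no movement. This position now holds a compound that reaches the end of the measurable range, and the step between compound 1 and compound 4 cannot be read, so the swap of pyrimidin-5-yl for pyridin-3-yl gets no size: the limit of > 100000 nM in this assay, at which 2 of the 4 values shown sit.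

From the compounds shown here alone, how far compound 4 really lies from compound 2 and compound 3 remains open, and so does whether fluoro differs from chloro at all once both can be read as numbers. Also open, going by these compounds, is what an amine or a carboxylic acid on the aromatic group at this carbon would do to the reading in this assay.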